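A chloro-for-fluoro swap on the pendant aryl ring

The source may hold more compounds than are shown below. What is called first, only, known or untested is meant among the compounds shown, and "the series" means these compounds.

Compound 1 `CCOC(=O)C12C(=O)OCC=C1COC2c1ccccc1` gives 12800 nM in a functional assay on HeLa cells (Homo sapiens) for cytotoxicity, read by MTT assay; on this read-out lower numbers stand for stronger inhibition and higher numbers for weaker inhibition. Compound 2 `CCOC(=O)C12C(=O)OCC=C1COC2c1ccccc1F` gives 22100 nM. Compound 3 `CCOC(=O)C12C(=O)OCC=C1COC2c1ccc(F)cc1` gives 22900 nM.

Compound 3 sits within the scatter of both others: a 1.8-fold higher number from compound 1 to compound 3 (0.25 log units; within the scatter) and a 1.0-fold higher number from compound 2 to compound 3 (0.02 log units; within the scatter). Compound 4 `CCOC(=O)C12C(=O)OCC=C1COC2c1cccc(Cl)c1` differs from compound 3 by 3-chlorophenyl in place of 4-fluorophenyl on a saturated ring carbon. Within the data shown here, the steps that bear on it are the two fluoro additions, a 1.7-fold higher number from compound 1 to compound 2 (0.24 log units; within the scatter) and a 1.8-fold higher number from compound 1 to compound 3 (0.25 log units; within the scatter), and the move of fluoro between ring positions, a 1.0-fold higher number from compound 2 to compound 3 (0.02 log units; within the scatter), none beyond the scatter. Among the measured compounds shown here, no chloro analogue has been measured, so a step is expected of the same modest size, with no clear direction, in this assay: a 1.0-fold lower number from compound 3 to compound 4 (0.02 log units; within the scatter). Compound 4 is therefore estimated at 22000 nM, between 9000 nM and 50000 nM.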

Compound 4, half-maximal inhibitory concentration: > 1000000 nM
Compound 4: a limit, no number; the forecaster's own chance of this, stated with the estimate: 10%; middle value at least 45-fold (1.65 log units) away from the limit.
By their numbers in this assay, from the lowest: compounds 1, 2 and 3 (each within the scatter of the next). At a limit, above all of these: compound 4.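

In this assay, compound 4 carries a limit of the assay and not a number: the limit of > 1000000 nM in this assay, at which 1 of the 4 values shown sits.

Even so, the group on this saturated ring carbon can clearly shift the read-out, which the fluoro changes did not show: the steps are an at least 43-fold higher number from compound 3 to compound 4 (1.64 log units; beyond the scatter), an at least 45-fold higher number from compound 2 to compound 4 (1.65 log units; beyond the scatter) and an at least 78-fold higher number from compound 1 to compound 4 (1.89 log units; beyond the scatter). All three lie beyond the scatter, whereas every step among compound 1, compound 2 and compound 3 stayed within it.

The compounds shown do not separate the effect of the chloro from that of its ring position. From the compounds shown here alone, how a bromo, a methoxy or an amine on the aryl ring would read here also stays open.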